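Series notes: amine head group on the hydroxylated chain

A few compounds are considered here, and "the series" means these few. Any claim that something is new, unique, unknown or untested is made for them only; others in the source may bear on it.

Compound 1, `CCCCCCCCCCc1ccc(-c2noc(CCCN(C)C)n2)cc1`, gives 8% in an assay on HeLa cells for inhibition of sphingosine-1-phosphate transporter SPNS2 (Mus musculus), read by LC-MS, tested at 2 uM; a higher number here means more inhibition at the concentration tested (going by the name of the read-out), a lower number less inhibition.
Compound 2, `CCCCCCCCCCc1ccc(-c2noc(CC(O)CN3CCCC3)n2)cc1`, gives 21% in this assay.

On the numbers shown compound 2 stands highest of the two; the only measured step, a number 13 percentage points higher from compound 1 to compound 2 (beyond the scatter), separates it from compound 1. Compound 3, `CCCCCCCCCCc1ccc(-c2noc(CC(O)CN(C)C)n2)cc1`, is next. Against compound 2 the change is dimethylamino in place of pyrrolidin-1-yl on a saturated chain carbon, two bonds along the chain from an oxygen on a saturated carbon. The step from compound 1 to compound 2 bears on this only in part, since it exchanged amine and added the hydroxyl together, whereas here the hydroxyl stays and only the amine changes. A small fall, or none beyond the scatter, is therefore expected in this assay, the expected step being a number 7 percentage points lower from compound 2 to compound 3 (within the scatter). For compound 3 the estimate is 14%, between 5% and 25%.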

Compound 3, a percentage reported as inhibition, at one concentration (the size of the read-out at that concentration, not a potency): 61%
The estimate for compound 3 lay 47 percentage points below the measured number, and the stated range ends below it.
By their numbers in this assay, from the lowest: compound 1; then compound 2; then compound 3.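

With the hydroxy held, the amine alone proves decisive in this assay: dimethylamino in place of pyrrolidin-1-yl gives a number 40 percentage points higher from compound 2 to compound 3 (beyond the scatter), a change the earlier pair could not separate. With dimethylamino held, hydroxy in place of hydrogen gives a number 53 percentage points higher from compound 1 to compound 3 (beyond the scatter), so the modest earlier step combined one change that raises the number with another that lowers it. No evidence here accounts for either step. Open, as far as these compounds go, is how other amines, such as diethylamino or piperidin-1-yl, behave on the hydroxylated chain, and whether a methoxy group can stand in for the hydroxy.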